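Iodo for methyl at the far phenyl of a phosphoserine ester

The source may report more compounds than this note shows. Statements on the series, on what has been measured and on what is new or still open speak of the compounds shown alone.

Compound 1 `CCCCCCCCCCCOc1ccccc1CCC(=O)OCCCOP(=O)(O)OC[C@H](N)C(=O)O`: 14.6%
Compound 2 `Cc1ccc(Oc2cccc(COc3ccccc3CCC(=O)OCCCOP(=O)(O)OC[C@H](N)C(=O)O)c2)cc1`: 18.2%

In an assay on cells for agonist activity at probable G-protein coupled receptor 34 (Mus musculus), with a stated time of 1 h (a higher number here means a larger maximal response, a lower number a smaller maximal response), compound 2 gives 18.2%, the higher of the two numbers, while compound 1 gives 14.6%, a value that lies within the scatter of compound 2. Compound 3 `N[C@@H](COP(=O)(O)OCCCOC(=O)CCc1ccccc1OCc1cccc(Oc2ccc(I)cc2)c1)C(=O)O` differs from compound 2 by iodo in place of methyl on an aromatic carbon. Within the data shown here, no step between measured compounds is known, so the size of this change is uncertain; the step of a number 2.8 percentage points higher from compound 2 to compound 3 (within the scatter) is expected to be small, possibly a slight rise, within the scatter. The maximal response of compound 3 is estimated at 21%, with a range from 10% to 33%.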

Compound 3, largest response reached (Emax), in percent of the reference or control that the assay uses: 19.1%
Compound 3: middle estimate off by 1.9 percentage points, on the high side; low and high end bracket the measured number.
By their numbers in this assay, from the lowest: compounds 1, 2 and 3 (each within the scatter of the next).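

In this assay, replacing 4-methylphenoxy with 4-iodophenoxy gives a number 0.9 percentage points higher from compound 2 to compound 3 (within the scatter), so at this place, para to a large group, iodo and methyl cannot be told apart. Among these compounds, this is the first step that can be read at a single place, since compound 1 and compound 2 differ in more than one. No measured evidence here speaks to what lies behind this result. On these data alone, it remains open whether an amine or a carboxylic acid at this carbon would move the maximal response beyond the scatter.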